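Ethyl for methyl on the core nitrogen: compound 4

A few compounds are considered here, and "the series" means these few. Any claim that something is new, unique, unknown or untested is made for them only; others in the source may bear on it.

Going by the values given here, the three measured members share one core and differ only in the group on the aromatic carbon of the aniline: compound 1 `Cn1nc(-c2ccnc(Nc3ccc(O)cc3)n2)c2ccccc21` carries hydroxy, compound 2 `Cn1nc(-c2ccnc(Nc3ccc([N+](=O)[O-])cc3)n2)c2ccccc21` nitro, compound 3 `Cn1nc(-c2ccnc(Nc3ccc(S(N)(=O)=O)cc3)n2)c2ccccc21` sulfamoyl. In a functional assay on HCT-116 cells (Homo sapiens) for antiproliferative activity, read by MTT assay, with a stated time of 72 h (on this read-out lower numbers stand for stronger inhibition of growth and higher numbers for weaker inhibition of growth), compound 1 gives 8430 nM, compound 2 gives 8220 nM and compound 3 gives 2280 nM. Compound 2 sits next to compound 1, the two within the scatter of each other (a 1.0-fold lower number from compound 1 to compound 2 (0.01 log units; within the scatter)), and a modest step away from compound 3 (a 3.6-fold lower number from compound 2 to compound 3 (0.56 log units; beyond the scatter)); the remaining step, a 3.7-fold lower number from compound 1 to compound 3 (0.57 log units; beyond the scatter), is of the same size.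

Compound 4 `CCn1nc(-c2ccnc(Nc3ccc([N+](=O)[O-])cc3)n2)c2ccccc21` differs from compound 2 by methyl in place of hydrogen on a saturated chain carbon bound to an aromatic nitrogen, which read one bond further out is methyl to ethyl. Among the compounds with values here, none of the measured steps touches this position: all three vary the group on the aromatic carbon while the chain on the aromatic nitrogen is held fixed. There is thus no basis for expecting a step beyond the scatter in this assay in either direction. The expected step is a 1.0-fold lower number from compound 2 to compound 4 (0.01 log units; within the scatter). Compound 4 is estimated at 8000 nM in this assay, within 3000 nM to 22000 nM.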

Compound 4, concentration for 50% growth inhibition: 4060 nM
Compound 4: middle estimate off by 2.0-fold (0.29 log units), on the high side, and the stated range covers the measured number.
By their numbers in this assay, from the lowest: compounds 3 and 4 (each within the scatter of the next); then compounds 2 and 1 (each within the scatter of the next).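

The chain on the aromatic nitrogen is not a silent position: in this assay methyl in place of hydrogen on the saturated chain carbon bound to that nitrogen gives a 2.0-fold lower number from compound 2 to compound 4 (0.31 log units; beyond the scatter) as a modest step beyond the scatter. Going by these compounds alone, the earlier steps all held this chain fixed, so this is the first sign that the number responds to it, and here a change of one carbon, methyl to ethyl, is enough. No measurement at hand bears on the origin of this step.

Open, on these data alone, is whether the same change carries over when hydroxy or sulfamoyl replaces nitro on the aromatic carbon. Also open, as far as these compounds go, is whether a longer chain such as propyl, or a chain ending in an amine or a carboxylic acid, on the same nitrogen would move the number further or reverse the step.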